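The compounds below may be only part of what the source reports. "The series", "measured", "known", "first", "only" and "open" are said of these compounds alone.

Working notes on the series. Going by the values given here, in a functional assay on HL-60 cells (Homo sapiens) for cytotoxicity, read by MTT assay (a higher number here means a weaker inhibitor, a lower number a stronger inhibitor), compound 1 (`Cc1ccccc1S(=O)(=O)NC(C)C1=CC(=O)c2c(O)ccc(O)c2C1=O`) gives 70 nM and compound 2 (`COc1ccc(S(=O)(=O)NC(C)C2=CC(=O)c3c(O)ccc(O)c3C2=O)c(OC)c1`) gives 500 nM as the higher of the only two numbers available, which makes compound 2 the weaker inhibitor of the pair. Compound 3 (`CC(NS(=O)(=O)c1ccc(Cl)cc1)C1=CC(=O)c2c(O)ccc(O)c2C1=O`) has not yet been measured. Its difference from compound 2 is 4-chlorophenyl in place of 2,4-dimethoxyphenyl on a sulfonyl sulfur. Among the compounds with values here, one measured step bears on this change, and it sits at the same sulfonyl sulfur: a 7.1-fold higher number from compound 1 to compound 2 (0.85 log units; beyond the scatter) (2,4-dimethoxyphenyl in place of 2-methylphenyl). Compound 3 loses the group that came in with that modest step, so part of that rise may be reversed. Within the data shown here, no measured compound carries 4-chlorophenyl, and a single step gives no basis for expecting the whole rise to be reversed. An estimated step of a 2.9-fold lower number from compound 2 to compound 3 (0.47 log units; beyond the scatter) (toward a lower number, and smaller than the measured one) is therefore expected in this assay for this change. Compound 3 is expected at an estimated 170 nM (range 55 nM to 520 nM).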

Compound 3, half-maximal inhibitory concentration: 250 nM
Beside the measured number, compound 3's estimate is 1.5-fold (0.17 log units) below it; the range from low to high includes it.
By their numbers in this assay, from the lowest: compound 1; then compounds 3 and 2 (each within the scatter of the next).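

In this assay, the change at the sulfonyl sulfur gives a 2.0-fold lower number from compound 2 to compound 3 (0.30 log units; within the scatter), so 2,4-dimethoxyphenyl and 4-chlorophenyl cannot be told apart here, although the entering group carries no hydrogen-bond acceptors and the leaving group does. The new comparison with 2-methylphenyl gives a 3.6-fold higher number from compound 1 to compound 3 (0.55 log units; beyond the scatter), so two different groups now stand beyond the scatter from compound 1, which holds the lowest number of the three, and the gap seen earlier is no longer tied to 2,4-dimethoxyphenyl alone. No measured data on these compounds offer an explanation for this separation of 2-methylphenyl from the other two groups.

What the compounds shown leave open is whether the lower number of compound 1 depends on its methyl group or holds for other groups on the sulfonyl sulfur, a question that an unsubstituted phenyl would address directly. Going by these compounds, it is also open how far this position tolerates a change away from an aromatic ring, for instance to a butyl chain, or a group bearing an amine or a carboxylic acid.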